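This account rests on a few compounds, and the source may have more. Where it says the series, first, only, none or still open, it means among the compounds named here.

Measured so far in a functional assay (Homo sapiens) for inhibition of Nucleic Acid, tested at 100 uM; a higher number here means more inhibition at the concentration tested (going by the name of the read-out), a lower number less inhibition:
Compound 1 `CSc1nccc2c1ncn2C1O[C@H](CO)[C@@H](O)[C@H]1O` gives 24%.
Compound 2 `[N-]=[N+]=Nc1nccc2c1ncn2C1O[C@H](CO)[C@@H](O)[C@H]1O` gives 4%.

Compound 2 stands lowest of the two numbers; its nearest neighbour is compound 1, which lies above it by a step beyond the scatter. For the measured compounds named here, the only measured step, a number 20 percentage points lower from compound 1 to compound 2 (beyond the scatter), swapped one small group for another at the same position on the shared core and moved the read-out by a modest amount.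

Compound 3 `CCCCCCNc1nccc2c1ncn2C1O[C@H](CO)[C@@H](O)[C@H]1O` differs from compound 2 by hexylamino in place of azido on an aromatic carbon. Going by the values given here, neither measured compound carries a hexylamino group, so no measured step matches this change directly; the single step from compound 1 to compound 2 shows only that exchanging the group at this position shifts this assay modestly. Because the step of a number 20 percentage points lower from compound 1 to compound 2 (beyond the scatter) was modest, a step of comparable size is expected here, most likely upward but without certainty. Compound 3 is therefore expected to give about 12%, with a range from -5% to 35%. The implied step, a number 8 percentage points higher from compound 2 to compound 3 (within the scatter), is an expectation only.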

Compound 3, a percentage reported as inhibition, at one concentration (the size of the read-out at that concentration, not a potency): 8%
Compound 3: the middle estimate sits 4 percentage points above what was measured, and the stated range covers the measured number.
By their numbers in this assay, from the lowest: compounds 2 and 3 (each within the scatter of the next); then compound 1.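

In this assay, hexylamino in place of azido on this aromatic carbon gives a number 4 percentage points higher from compound 2 to compound 3 (within the scatter) and so leaves the two compounds indistinguishable, even though hexylamino brings a chain and a hydrogen-bond donor that azido lacks. Hexylamino in place of methylsulfanyl gives a number 16 percentage points lower from compound 1 to compound 3 (beyond the scatter) as a clear drop, so compound 1 now stands apart from two quite different replacements at this position rather than from azido alone. Nothing available explains why the methylsulfanyl compound gives the highest number of the three.

From the compounds shown here alone, it remains open whether a small amine such as methylamino, or an oxygen-linked group such as methoxy, would read like compound 1 or like compound 2 and compound 3. Going by these compounds, it is also open whether the sulfur of compound 1 matters for its higher number or whether a longer sulfur-linked chain such as hexylsulfanyl would keep it, and a butyl or octyl chain on the same nitrogen would show whether chain length on the amine changes the read-out at all.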